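Amide terminus swap in the shared core series

A few compounds are considered here, and "the series" means these few. Any claim that something is new, unique, unknown or untested is made for them only; others in the source may bear on it.

Measured so far:
compound 1 `CC(C)(C)OC(=O)NCCCCNc1cc(/C=C/c2ccccc2)nc2ccccc12` — 3700 nM
compound 2 `O=C(CN1CCCC1)NCCNc1cc(/C=C/c2ccccc2)nc2ccccc12` — 12500 nM

In an ADME assay on J774 cells (Mus musculus) for cytotoxicity, read by MTT assay, with a stated time of 48 h (on this read-out higher numbers stand for weaker inhibition and lower numbers for stronger inhibition), compound 2 has the higher of the two numbers, the step of a 3.4-fold higher number from compound 1 to compound 2 (0.53 log units; beyond the scatter) separating it from compound 1. Compound 3 `O=C(CNc1ccccc1)NCCNc1cc(/C=C/c2ccccc2)nc2ccccc12` carries anilino in place of pyrrolidin-1-yl on a saturated chain carbon bound to a carbonyl carbon. Within the data shown here, the only measured step, a 3.4-fold higher number from compound 1 to compound 2 (0.53 log units; beyond the scatter), altered a different part of the side chain, so it bears on this change only loosely; no measured pair isolates the amide terminus. A step of no more than modest size, in either direction, is therefore expected, a 1.3-fold lower number from compound 2 to compound 3 (0.10 log units; within the scatter). Compound 3 is estimated at 10000 nM, range 3000 nM to 30000 nM.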

Compound 3, half-maximal inhibitory concentration: 7800 nM
Estimate against measurement, compound 3: 1.3-fold (0.11 log units) above, and the stated range covers the measured number.
By their numbers in this assay, from the lowest: compound 1; then compounds 3 and 2 (each within the scatter of the next).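

In this assay, among these compounds, anilino in place of pyrrolidin-1-yl on a saturated chain carbon bound to a carbonyl carbon gives a 1.6-fold lower number from compound 2 to compound 3 (0.20 log units; within the scatter), the first measured step confined to the amide terminus. A five-membered non-aromatic ring can thus give way to a six-membered aromatic ring of carbon only, with a hydrogen-bond donor gained, and the number stays within the scatter. No available evidence bears on this result. Open, as far as these compounds go, is whether a carboxylic acid or morpholin-4-yl on that carbon would also stay within the scatter of compound 2.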